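A few compounds are considered here, and "the series" means these few. Any claim that something is new, unique, unknown or untested is made for them only; others in the source may bear on it.

Measured compounds:
compound 1, `Cc1cc(-c2cccc(F)c2)cc(C)c1Nc1ccnc(Nc2ccc(C#N)cc2)n1`, 4120 nM
compound 2, `Cc1cc(-c2ccc(C(F)(F)F)cc2)cc(C)c1Nc1ccnc(Nc2ccc(C#N)cc2)n1`, 4160 nM
compound 3, `Cc1cc(-c2ccccc2F)cc(C)c1Nc1ccnc(Nc2ccc(C#N)cc2)n1`, 2120 nM

In an ADME assay on MT4 cells (Homo sapiens) for cytotoxicity, read by MTT assay, with a stated time of 4 days (on this read-out lower numbers stand for higher toxicity in this test and higher numbers for lower toxicity in this test), the three measured compounds sit close together. Compound 1 stands among them with its steps to both neighbours inside the scatter: the step of a 1.0-fold higher number from compound 1 to compound 2 (0.00 log units; within the scatter) is essentially nil, and the step of a 1.9-fold lower number from compound 1 to compound 3 (0.29 log units; within the scatter) is also within the scatter, as is the step of a 2.0-fold lower number from compound 2 to compound 3 (0.29 log units; within the scatter) between the other two. In short, none of the three can be told apart on this read-out.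

Compound 4, `Cc1ccc(-c2cc(C)c(Nc3ccnc(Nc4ccc(C#N)cc4)n3)c(C)c2)cc1`, has not yet been measured. It differs from compound 1 in one place: 4-methylphenyl in place of 3-fluorophenyl on an aromatic carbon. This is the same kind of change as the ones already seen, an exchange of one aryl group for another on the aromatic carbon that is para to the large group. All three measured steps of that kind, a 1.0-fold higher number from compound 1 to compound 2 (0.00 log units; within the scatter), a 1.9-fold lower number from compound 1 to compound 3 (0.29 log units; within the scatter) and a 2.0-fold lower number from compound 2 to compound 3 (0.29 log units; within the scatter), stayed within the scatter, so no step beyond the scatter is expected here either, in either direction.

Compound 4 is therefore expected to give about 4000 nM in this assay, with a likely range from 2000 nM to 8000 nM. The expected step is a 1.0-fold lower number from compound 1 to compound 4 (0.01 log units; within the scatter).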

Compound 4, half-maximal cytotoxic concentration: 5570 nM
The estimate for compound 4 lay 1.4-fold (0.14 log units) below the measured number; the measured number falls inside the stated range.
By their numbers in this assay, from the lowest: compounds 3, 1, 2 and 4 (each within the scatter of the next, the first and the last beyond it).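

In this assay, an exchange of one aryl group for another on this aromatic carbon now gives its first step beyond the scatter (a 2.6-fold higher number from compound 3 to compound 4 (0.42 log units; beyond the scatter)), so the choice of aryl group at this position can register on this read-out, though only modestly. That separation holds for one pair alone: 4-methylphenyl stays within the scatter of 3-fluorophenyl (a 1.4-fold higher number from compound 1 to compound 4 (0.13 log units; within the scatter)) and of 4-(trifluoromethyl)phenyl (a 1.3-fold higher number from compound 2 to compound 4 (0.13 log units; within the scatter)), and neither compound 1 nor compound 2 can be told apart from compound 3 or compound 4. No measurement at hand bears on what lies behind this one step, and it stands here as an observation only.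

The compounds shown carry only phenyl rings with a single fluorine, methyl or trifluoromethyl group at this position, so it remains open how a phenyl ring bearing an amine or a carboxylic acid, or a pyridine ring in its place, would read. Going by these compounds, it also remains open whether 2-methylphenyl or 4-fluorophenyl would fall with compound 3 or with compound 4, which would show whether the step follows the kind of group or where it sits on the phenyl ring.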